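A few compounds are considered here, and "the series" means these few. Any claim that something is new, unique, unknown or untested is made for them only; others in the source may bear on it.

Measured compounds:
- compound 1, `Nc1ncnn2c([C@@H]3O[C@H](CO)[C@@H](O)[C@H]3O)cc(C#CC3CC3)c12`: 30 nM
- compound 2, `Nc1ncnn2c([C@@H]3O[C@H](CO)[C@@H](O)[C@H]3O)cc(C#Cc3cccs3)c12`: > 100000 nM
- compound 3, `Nc1ncnn2c([C@@H]3O[C@H](CO)[C@@H](O)[C@H]3O)cc(-c3ccccc3)c12`: 75100 nM

In a functional assay on LN-229 cells (Homo sapiens) for antiproliferative activity, with a stated time of 72 h (a lower number here means a stronger inhibitor, a higher number a weaker inhibitor), compound 1 gives 30 nM. Compound 2 reaches only a limit of the assay, > 100000 nM, so no number is known for it; (the limit of > 100000 nM in this assay, at which 1 of the 3 values shown sits). Compound 3 gives 75100 nM, the highest of the two numbers, and the step to its nearest neighbour is a 2500-fold higher number from compound 1 to compound 3 (3.40 log units; beyond the scatter), while an at least 1.3-fold lower number from compound 2 to compound 3 (0.12 log units; that floor lies within the scatter). Compound 3 thus stands among the weak inhibitors of this small set.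

Compound 4, `Nc1ncnn2c([C@@H]3O[C@H](CO)[C@@H](O)[C@H]3O)cc(-c3ccc(Cl)cc3)c12`, differs from compound 3 by chloro in place of hydrogen on an aromatic carbon. For the measured compounds named here, no measured step changes a substituent on the phenyl ring; the steps seen so far, an at least 3300-fold higher number from compound 1 to compound 2 (3.52 log units; beyond the scatter) and a 2500-fold higher number from compound 1 to compound 3 (3.40 log units; beyond the scatter), concern the replacement of the whole side group. Both show that the larger aromatic side groups of compound 2 and compound 3 sit far weaker than compound 1, but they say nothing about how a chloro group on the phenyl ring would shift the number. The expected step in this assay is therefore a 1.3-fold lower number from compound 3 to compound 4 (0.10 log units; within the scatter), a change not expected beyond the scatter. Compound 4 is estimated at 60000 nM, with a range from 15000 nM to 250000 nM.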

Compound 4, half-maximal inhibitory concentration: 32600 nM
Compound 4: middle estimate off by 1.8-fold (0.26 log units), on the high side; low and high end bracket the measured number.
By their numbers in this assay, from the lowest: compound 1; then compound 4; then compound 3. At a limit, above all of these: compound 2.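

Adding chloro to the phenyl ring is the first change shown that alters the ring itself instead of replacing the whole side group, and in this assay it gives a 2.3-fold lower number from compound 3 to compound 4 (0.36 log units; beyond the scatter), so this place on the ring responds to a single added heavy atom, though only modestly. That shift is small against the gap that remains, a 1100-fold higher number from compound 1 to compound 4 (3.04 log units; beyond the scatter), so 4-chlorophenyl recovers very little of what is lost when 2-cyclopropylethynyl is replaced. The comparison with the compound at the limit also sharpens, with an at least 3.0-fold lower number from compound 2 to compound 4 (0.48 log units; beyond the scatter) now clear of the scatter, whereas an at least 1.3-fold lower number from compound 2 to compound 3 (0.12 log units; that floor lies within the scatter) was not, although both steps rest on a limit of the assay and not on a number: the limit of > 100000 nM in this assay, at which 1 of the 4 values shown sits.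

Chloro is the only substituent shown on this ring, and it sits at only one place, para to a large group, so it remains open whether fluoro, methoxy or an amine there would move the number further or in the other direction. As far as these compounds go, it also remains open whether another small group on the triple bond, such as methyl or cyclobutyl, would keep the strength of compound 1.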